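This account rests on a few compounds, and the source may have more. Where it says the series, first, only, none or still open, it means among the compounds named here.

Measured so far:
Compound 1, `Cc1ccc2c(Sc3cc(Cl)cc(Cl)c3)c(CCCC(N)=O)[nH]c2c1`, in an ADME assay on BSC-1 cells (Chlorocebus aethiops) for cytotoxicity, read by LDH release, with a stated time of 20 h (a lower number here means that less compound is tolerated, a higher number that more compound is tolerated), gives >= 100000 nM; this value is a limit of the assay.
Compound 2, `Cc1ccc2c(Sc3cc(Cl)cc(Cl)c3)c(CCC(=O)O)[nH]c2c1`, in this assay gives 36000 nM.

For the measured compounds named here, compound 2 carries the only numerical value shown; the other measured compound, compound 1, sits at the limit of >= 100000 nM in this assay, at which 1 of the 2 values shown sits. Going by the values given here, the one measured step, an at least 2.7-fold lower number from compound 1 to compound 2 (0.44 log units; beyond the scatter), is the sole reference for how a change at the chain end moves this read-out. Compound 3, `CCCCCCNC(=O)CCc1[nH]c2cc(C)ccc2c1Sc1cc(Cl)cc(Cl)c1`, is not yet measured; it differs from compound 2 by hexylamino in place of hydroxy on a carbonyl carbon. Among the compounds with values here, the measured step exchanged carbamoylmethyl for carboxy; the change to compound 3 again alters the carbonyl substituent, hydroxy to hexylamino, so that reference bears on it only loosely, and no measured step covers a hexylamino group. For compound 3 the number is expected to stay near that of compound 2, with a 1.1-fold higher number from compound 2 to compound 3 (0.05 log units; within the scatter) within the scatter. Compound 3 is estimated at 40000 nM, between 12000 nM and 130000 nM.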

Compound 3, half-maximal cytotoxic concentration: 27000 nM
Beside the measured number, compound 3's estimate is 1.5-fold (0.17 log units) above it; the range from low to high includes it.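

In this assay, hexylamino in place of hydroxy on a carbonyl carbon gives a 1.3-fold lower number from compound 2 to compound 3 (0.12 log units; within the scatter), so this read-out does not separate the carboxylic acid from the hexyl amide at this position. Measured against compound 1, the new amide gives an at least 3.7-fold lower number from compound 1 to compound 3 (0.56 log units; beyond the scatter), which places compound 3 on the same side of compound 1 as compound 2. The value of compound 1 is a limit, so the true size of both steps from it stays undefined: the limit of >= 100000 nM in this assay, at which 1 of the 3 values shown sits.

Still open, as far as these compounds go, is whether an unsubstituted amino group on the same carbonyl carbon would stay with compound 2 and compound 3 or move toward compound 1. Also open, from the compounds shown here alone, is how a shorter alkylamino group, a cyclic amine or a basic amine at the chain end would read here.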